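The compounds below may be only part of what the source reports. "The series", "measured", "known", "first", "only" and "open" are said of these compounds alone.

In a functional assay on SK-MEL-28 cells (Homo sapiens) for cytotoxicity, read by sulforhodamine B assay, with a stated time of 48 h, tested at 10 uM (a higher number here means a weaker effect of the compound at the concentration tested, a lower number a stronger effect), three compounds built on a shared core have been measured. Compound 3 `COc1ccc(-c2cc(/C=C/C(=O)c3ccc(N)cc3)[nH]n2)cc1OC` gives -29%. Compound 1 `COc1cc(-c2cc(/C=C/C(=O)c3ccc(N)cc3)[nH]n2)cc(OC)c1OC` gives -57%; it differs from compound 3 by one change, (methoxy in place of hydrogen on an aromatic carbon), and that step was a number 28 percentage points lower from compound 3 to compound 1 (beyond the scatter). Compound 2 `COc1ccc(C(=O)/C=C/c2cc(-c3cc(OC)c(OC)c(OC)c3)n[nH]2)cc1OC` gives -88%, the lowest of the three; the step of a number 31 percentage points lower from compound 1 to compound 2 (beyond the scatter) came from 3,4-dimethoxyphenyl in place of 4-aminophenyl on a carbonyl carbon. How the core of compound 2 differs from the core of compound 3 is not broken down here. Compound 4 `COc1cc(C(=O)/C=C/c2cc(-c3cc(OC)c(OC)c(OC)c3)n[nH]2)cc(OC)c1OC` is not yet measured; it differs from compound 2 by methoxy in place of hydrogen on an aromatic carbon, the same change as from compound 3 to compound 1, at a place described in the same words. Because compound 2 already gives -88%, a read-out near the lower end of this measurement, the expected step of a number 7 percentage points lower from compound 2 to compound 4 (within the scatter) is smaller than the earlier one. Compound 4 is expected to give about -95%, between -100% and -84%.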

Compound 4, a percentage reported as activity, at one concentration (the size of the read-out at that concentration, not a potency): -92%
For compound 4 the middle estimate is 3 percentage points below the measured one; the measured number falls inside the stated range.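

On the core of compound 2, putting methoxy in place of hydrogen gives a number a number 4 percentage points lower from compound 2 to compound 4 (within the scatter) in this assay. The same change does not bring a step of the same size on both cores: the same change on two cores in this assay, a number 28 percentage points lower (beyond the scatter) from compound 3 to compound 1 and a number 4 percentage points lower (within the scatter) from compound 2 to compound 4, 24 percentage points apart, beyond the scatter of two such steps

Among the compounds shown here, this rests on only two pairs of compounds, and compound 2, at -88%, already lies near the lower end of the read-out; the data therefore do not show that methoxy is without effect on this core, or why the two steps differ.

Still open, from the compounds shown here alone, is how a hydroxy group, an amine or a longer chain such as ethoxy would behave at this place on either core. Going by these compounds, with one concentration per compound, whether the effect would be stronger or weaker at other concentrations also remains open.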